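Sulfamoyl in Place of Fluoro on the Anilide Ring

A few compounds are considered here, and "the series" means these few. Any claim that something is new, unique, unknown or untested is made for them only; others in the source may bear on it.

Measured compounds in this set:
compound 1 `CC(C)n1ncc2c(C(=O)Nc3ccc(F)c(F)c3)cc(-c3cccs3)nc21`: > 200000 nM
compound 2 `CC(C)n1ncc2c(C(=O)Nc3cc(F)ccc3F)cc(-c3cccs3)nc21`: 100000 nM
compound 3 `CC(C)n1ncc2c(C(=O)Nc3ccc(F)c(S(N)(=O)=O)c3)cc(-c3cccs3)nc21`: 50000 nM

The three share one core and differ only in the ring on the amide-type nitrogen. In an ADME assay on LLC-MK2 cells (Macaca mulatta) for cytotoxicity, read by spectrophotometry and crystal violet staining, with a stated time of 4 days (a higher number here means that more compound is tolerated, a lower number that less compound is tolerated), compound 1 gives > 200000 nM; this is a limit of the assay, not a number (the limit of > 200000 nM in this assay, at which 1 of the 3 values shown sits). Compound 2 gives 100000 nM and compound 3 gives 50000 nM. Compound 2 differs from compound 1 in its ring: 2,5-difluorophenyl in place of 3,4-difluorophenyl on an amide-type nitrogen, with an at least 2.0-fold lower number from compound 1 to compound 2 (0.30 log units; that floor lies within the scatter). Compound 3 differs from compound 1 by sulfamoyl in place of fluoro on an aromatic carbon, giving an at least 4.0-fold lower number from compound 1 to compound 3 (0.60 log units; beyond the scatter).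

Compound 4 `CC(C)n1ncc2c(C(=O)Nc3cc(S(N)(=O)=O)ccc3F)cc(-c3cccs3)nc21` has not been measured. It differs from compound 2 by sulfamoyl in place of fluoro on an aromatic carbon. This is the same kind of change as from compound 1 to compound 3, but the surroundings differ: in compound 3 the new group sits ortho to a fluoro group and meta to a large group, while in compound 4 it sits meta to a large group and para to a fluoro group. The expected step is a 3.3-fold lower number from compound 2 to compound 4 (0.52 log units; beyond the scatter), resting on an at least 4.0-fold lower number from compound 1 to compound 3 (0.60 log units; beyond the scatter). Compound 4 is therefore estimated at 30000 nM, expected to fall between 10000 nM and 100000 nM.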

Compound 4, half-maximal cytotoxic concentration: 25000 nM
The estimate for compound 4 lay 1.2-fold (0.08 log units) above the measured number, within the range that was stated.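

In this assay, sulfamoyl in place of fluoro gives a 4.0-fold lower number from compound 2 to compound 4 (0.60 log units; beyond the scatter), so the change that lowered the tolerated concentration on the ring of compound 1 also lowers it on the ring of compound 2. This shows that the direction of the change carried over in these two pairs, but whether its size carried over as well stays unsettled: the same change on two cores in this assay, an at least 4.0-fold lower number (0.60 log units; beyond the scatter) from compound 1 to compound 3 and a 4.0-fold lower number (0.60 log units; beyond the scatter) from compound 2 to compound 4; the limit leaves it open whether they differ

Compound 1 stands at a limit of the assay, not at a number, so the earlier step has only a floor: the limit of > 200000 nM in this assay, at which 1 of the 4 values shown sits.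

The compounds shown leave open whether a different group in the same place, such as a carboxylic acid or an amine, would lower the number as much as sulfamoyl does. They also leave open whether the step holds when the shared core itself changes, and they speak only to tolerance in this assay, not to any other measure.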